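A few compounds are considered here, and "the series" means these few. Any claim that something is new, unique, unknown or untested is made for them only; others in the source may bear on it.

Among the compounds with values here, in a functional assay on LNCaP cells (Homo sapiens) for cytotoxicity, read by MTT assay, with a stated time of 48 h (a higher number here means a weaker inhibitor, a lower number a stronger inhibitor), compound 3 `Clc1ccc(-c2nc(-c3c[nH]c4ccccc34)co2)cc1` gives 505000 nM, the highest of the three numbers measured so far. Its nearest neighbour is compound 1 `COc1ccc(-c2nc(-c3c[nH]c4ccccc34)co2)cc1OC`, which gives 278000 nM in this assay, a gap within the scatter. Furthest away is compound 2 `Fc1ccc(-c2nc(-c3c[nH]c4ccccc34)co2)cc1`, which gives 59800 nM; the single swap of an 8.4-fold higher number from compound 2 to compound 3 (0.93 log units; beyond the scatter) is the only step that touches the same position. Compound 4 `COc1ccc(-c2nc(-c3c[nH]c4ccccc34)co2)cc1` differs from compound 3 by methoxy in place of chloro on an aromatic carbon. Within the data shown here, only that one modest halogen swap bears on the new change, and compound 1, which carries methoxy groups, sits within the scatter of compound 3. The expected step is therefore small, a 1.7-fold lower number from compound 3 to compound 4 (0.23 log units; within the scatter), and compound 4 is estimated at 300000 nM, in a range from 100000 nM to 900000 nM.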

Compound 4, half-maximal inhibitory concentration: 507000 nM
Compound 4: the middle estimate sits 1.7-fold (0.23 log units) below what was measured; the measured number falls inside the stated range.
By their numbers in this assay, from the lowest: compound 2; then compounds 1, 3 and 4 (each within the scatter of the next).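

In this assay, methoxy on this aromatic carbon, para to a large group, cannot be told apart from chloro (a 1.0-fold higher number from compound 3 to compound 4 (0.00 log units; within the scatter)), while the gap to fluoro lies beyond the scatter (an 8.5-fold higher number from compound 2 to compound 4 (0.93 log units; beyond the scatter)), so among these groups fluoro alone stands apart. A second methoxy group on the ring also makes no readable difference (a 1.8-fold higher number from compound 1 to compound 4 (0.26 log units; within the scatter)). Nothing available explains why fluoro stands apart.

Still open, on these data alone, is whether fluoro's lower number is specific to that group or would also appear with a nitrile, an amine or a carboxylic acid at this position. The compounds shown also leave open how the ring with no group there at all would compare.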